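A Ring Closes at a Stability Limit

A few compounds are considered here, and "the series" means these few. Any claim that something is new, unique, unknown or untested is made for them only; others in the source may bear on it.

Three related compounds have been tested so far in an in vitro ADME assay on microsomes (Rattus norvegicus) for metabolic stability (a higher number here means that the compound lasts longer, a lower number that the compound disappears faster), and none has given an exact number. Compound 1 (`Cc1c2c(n3c1CCCNC[C@H](C)Nc1cc-3ccc1C(N)=O)CC(C)(C)CC2=O`) gives > 0.5 h as a limit. Compound 2 (`Cc1c2c(n3c1CCN(C(=O)[C@H](C)N)CC[C@H](C)Nc1cc-3ccc1C(N)=O)CC(C)(C)CC2=O`) gives > 0.5 h as a limit too. Compound 3 (`CC[C@H](N)C(=O)N1CCc2c(C)c3c(n2-c2ccc(C(N)=O)c(c2)N[C@@H](C)[C@H](C)C1)CC(C)(C)CC3=O`) gives > 0.5 h in this assay and this is also a limit, not a number. The whole set stands at one mark (the limit of > 0.5 h in this assay, at which 3 of the 3 values shown sit) and these readings put the three compounds in no order.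

Compound 4 (`Cc1c2c(n3c1CCN(C(=O)C1(N)CCCC1)C[C@@H](C)[C@H](C)Nc1cc-3ccc1C(N)=O)CC(C)(C)CC2=O`) has yet to be measured. It differs from compound 3 in one place, on a carbonyl carbon whose other neighbour is an amide-type nitrogen in a ring, where 1-aminocyclopentyl stands in place of 1-aminopropyl (1-aminocyclopentyl in place of 1-aminopropyl on a carbonyl carbon). The entering group brings a five-membered non-aromatic ring of carbon only.

Going by the values given here, no measured pair shows what such a change does. Among the compounds with values here, the only guide is compound 3, whose limit is > 0.5 h. No shift beyond the usual scatter is expected in either direction, and the estimated change is a step that the limit leaves unreadable from compound 3 to compound 4 in this assay for this pair. Compound 4 is estimated at 0.7 h with an expected range of 0.35 h to 1.5 h in this measurement.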

Compound 4, half-life: 0.0833 h
Compound 4: the middle estimate sits 8.4-fold (0.92 log units) above what was measured; the whole stated range lies above it.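

In this assay, replacing 1-aminopropyl with 1-aminocyclopentyl on a carbonyl carbon whose other neighbour is an amide-type nitrogen in a ring gives a clear result: an at least 6.0-fold lower number from compound 3 to compound 4 (0.77 log units; beyond the scatter). This shows that the group at this position can shift the read-out, even though the two groups match in hydrogen-bond donors, hydrogen-bond acceptors and net charge and differ in the entering five-membered non-aromatic ring of carbon only and in having more heavy atoms. The reading for compound 4 also separates it from the other compounds, which had offered no order, and the rest of the set stays at one mark: the limit of > 0.5 h in this assay, at which 3 of the 4 values shown sit.

This single pair leaves open whether the ring itself or the added heavy atoms account for the step, a question that a 1-aminocyclopropyl group or an open-chain 1-aminobutyl group at the same place could help to address. Going by these compounds, compound 3 gives > 0.5 h, which is a limit and not a number, so the full size of the step also remains open.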